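The compounds below may be only part of what the source reports. "The series", "measured", "known", "first", "only" and "open" are said of these compounds alone.

Three triphosphates with a shared nucleobase-derived core were studied in an assay on cell membranes with P2Y purinoceptor 1 (Meleagris gallopavo) as the target; on this read-out lower numbers stand for an effect already at smaller amounts and higher numbers for an effect only at larger amounts of compound. Compound 1 `CCCCNc1nc(N)c2ncn([C@@H]3O[C@H](COP(=O)(O)OP(=O)(O)OP(=O)(O)O)[C@@H](O)[C@H]3O)c2n1` gives 39 nM in this assay. Compound 2 `CCCCSc1nc(N)c2ncn([C@@H]3O[C@H](COP(=O)(O)OP(=O)(O)OP(=O)(O)O)[C@@H](O)[C@H]3O)c2n1` gives 18 nM. Compound 3 `CCCCSc1nc2c(N)ncnc2n1[C@@H]1O[C@H](COP(=O)(O)OP(=O)(O)OP(=O)(O)O)[C@@H](O)[C@H]1O` has the same atoms as compound 2, joined differently; how the two cores differ is not broken down here. Compound 3 gives 10000 nM, the highest number of the three, which stands far from both compound 1 and compound 2.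

The change from compound 2 to compound 1 butylamino in place of butylsulfanyl on an aromatic carbon produced a 2.2-fold higher number from compound 2 to compound 1 (0.34 log units; beyond the scatter). The unmeasured compound 4 `CCCCNc1nc2c(N)ncnc2n1[C@@H]1O[C@H](COP(=O)(O)OP(=O)(O)OP(=O)(O)O)[C@@H](O)[C@H]1O` arises from compound 3 by the same kind of change (butylamino in place of butylsulfanyl on an aromatic carbon), but the place differs: in compound 1 the group sits on a six-membered aromatic ring with 2 nitrogen, meta to a fused ring, meta to an amino group and para to a fused ring, whereas in compound 4 it sits on a five-membered aromatic ring with 2 nitrogen, next to the ring atom that bears a large group. Within the data shown here, because the only measured example of this change is a 2.2-fold higher number from compound 2 to compound 1 (0.34 log units; beyond the scatter), compound 4 is expected to show a step of a 1.5-fold higher number from compound 3 to compound 4 (0.18 log units; within the scatter), with some added uncertainty since compound 3 already stands at the top of the measured range. On that basis compound 4 is estimated at 15000 nM, most plausibly between 5000 nM and 50000 nM.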

Compound 4, half-maximal effective concentration: 51000 nM
The estimate for compound 4 lay 3.4-fold (0.53 log units) below the measured number; measured number above the stated range.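

In this assay, butylamino in place of butylsulfanyl on an aromatic carbon of a five-membered aromatic ring with 2 nitrogen gave a 5.1-fold higher number from compound 3 to compound 4 (0.71 log units; beyond the scatter) and so moved the number the same way as on the other core. Set side by side, the two steps do not differ beyond what repeated measurement allows: the same change on two cores in this assay, a 2.2-fold higher number (0.34 log units; beyond the scatter) from compound 2 to compound 1 and a 5.1-fold higher number (0.71 log units; beyond the scatter) from compound 3 to compound 4, 2.4-fold (0.37 log units) apart, within the scatter of two such steps. This shows that, across the two cores shown here, the change raised the number both times and by amounts that cannot be told apart, even though the group sits in a different place on each core; it does not show why the step runs this way, and two pairs cannot establish that it would carry over to a third core.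

The compounds shown leave open how a butoxy group or a longer chain, such as hexylsulfanyl or hexylamino, would compare with butylsulfanyl and butylamino on either core. They also leave open whether the step between butylsulfanyl and butylamino would keep its direction and size with a diphosphate in place of the triphosphate.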